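The source may report more compounds than this note shows. Statements on the series, on what has been measured and on what is new or still open speak of the compounds shown alone.

In a functional assay on M14 cells (Homo sapiens) for cytotoxicity (on this read-out lower numbers stand for stronger inhibition of growth and higher numbers for weaker inhibition of growth), compound 3 `CSc1ccc(C2=C(c3ccc(OCC4CO4)cc3)C(=O)N3CCCC3C2)cc1` stands lowest of the three numbers at 90 nM while compound 1 `COc1ccc(C2=C(c3ccc(SC)cc3)CC3CCCN3C2=O)cc1C` gives 200 nM and compound 2 `CSc1ccc(C2=C(c3ccc(F)c(C)c3)C(=O)N3CCCC3C2)cc1` gives 800 nM on the same scale. Compound 4 `CSc1ccc(C2=C(c3ccc(C)cc3)C(=O)N3CCCC3C2)cc1` carries methyl in place of (oxiran-2-yl)methoxy on an aromatic carbon, para to a large group (methyl in place of (oxiran-2-yl)methoxy on an aromatic carbon). Going by the values given here, the one measured step bearing on this change is modest (a 4.0-fold higher number from compound 1 to compound 2 (0.60 log units; beyond the scatter)) and puts fluoro in place of methoxy on an aromatic carbon. Among the compounds with values here, no measured pair removes the (oxiran-2-yl)methoxy itself, so the basis is thin. A modest step of similar size toward a higher number is expected in this assay (a 3.3-fold higher number from compound 3 to compound 4 (0.52 log units; beyond the scatter)). For compound 4 the estimated value is 300 nM within an expected range (100 nM to 900 nM).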

Compound 4, concentration for 50% growth inhibition: 6000 nM
Estimate against measurement, compound 4: 20-fold (1.30 log units) below; the measured number lies above the stated range.
By their numbers in this assay, from the lowest: compound 3; then compound 1; then compound 2; then compound 4.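

In this assay, going by these compounds alone, the change from (oxiran-2-yl)methoxy to methyl, para to a large group, gives a 67-fold higher number from compound 3 to compound 4 (1.82 log units; beyond the scatter) and so is a large step, well past the one earlier step at an aromatic carbon. The same ring also responds when 4-methylphenyl replaces 4-fluoro-3-methylphenyl, with a 7.5-fold higher number from compound 2 to compound 4 (0.88 log units; beyond the scatter) as a modest step, and when it replaces 4-methoxy-3-methylphenyl, with a 30-fold higher number from compound 1 to compound 4 (1.48 log units; beyond the scatter) as a large one. No supporting evidence is available to explain these steps.

Still open, from the compounds shown here alone, is whether the three-membered ring itself matters or whether an open chain would serve equally. A plain methoxy, a 2,3-dihydroxypropoxy chain or an amine at this position on the core of compound 3 would separate these.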